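This account rests on a few compounds, and the source may have more. Where it says the series, first, only, none or still open, it means among the compounds named here.

Compound 1 `Cc1cc(Nc2cc(Cl)c(OC(F)F)c(Cl)c2)nc(N)n1`: > 63000 nM
Compound 2 `CCc1ccc(Nc2cc(C)nc(N)n2)cc1`: > 180000 nM

In an assay on cells for inhibition of S-adenosylmethionine decarboxylase proenzyme (Homo sapiens), read by mass spectrometry, at pH 7.2 (a lower number here means a stronger inhibitor, a higher number a weaker inhibitor), compound 1 gives > 63000 nM, which is a limit of the assay rather than a number. Compound 2 gives > 180000 nM, also a limit of the assay. Compound 2 therefore stands at the limit of > 180000 nM in this assay, at which 1 of the 2 values shown sits, and nothing more precise is known about it. Compound 3 `Cc1cc(Nc2ccc(C(F)(F)F)cc2)nc(N)n1` differs from compound 2 by trifluoromethyl in place of ethyl on an aromatic carbon. Within the data shown here, no measured step between two numbered compounds exists to draw on, so no move beyond the scatter is expected in this assay. Compound 3 is estimated at 150000 nM, in the range 40000 nM to 600000 nM. The step this estimate implies is an at least 1.2-fold lower number from compound 2 to compound 3 (0.07 log units; that floor lies within the scatter), expected to stay within the scatter.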

Compound 3, half-maximal inhibitory concentration: > 180000 nM
Compound 3: a limit, no number (the forecaster's own chance of this, stated with the estimate: 85%); middle value at least 1.2-fold (0.07 log units) from the limit.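

Compound 3 gives > 180000 nM, a limit and not a number. Among these compounds, compound 2 also sits at a limit, so no step between compound 2 and compound 3 can be read. Going by these compounds, whether trifluoromethyl or ethyl gives the stronger inhibitor remains open.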